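The compounds below may be only part of what the source reports. "The series", "measured", "known", "first", "only" and "open" are said of these compounds alone.

- compound 1 `COc1cc(OC)c(-c2coc3cc(OCC=C(C)C)ccc3c2=O)cc1OC`: 3800 nM
- compound 2 `COc1cc(OC)c(-c2coc3cc(OCc4ccc(F)cc4)ccc3c2=O)cc1OC`: > 10000 nM (a limit)

Both entries come from a functional assay on HUVEC cells (Homo sapiens) for antiproliferative activity, read by MTT assay, with a stated time of 24 h; on this read-out lower numbers stand for stronger inhibition and higher numbers for weaker inhibition. Compound 2 has no number there, only the limit > 10000 nM. That leaves it at the limit of > 10000 nM in this assay, at which 1 of the 2 values shown sits.

Compound 3 `COc1cc(OC)c(-c2coc3cc(OCc4ccc(C#N)cc4)ccc3c2=O)cc1OC` carries cyano in place of fluoro on an aromatic carbon, para to a large group: cyano in place of fluoro on an aromatic carbon. Going by the values given here, the only measured step, an at least 2.6-fold higher number from compound 1 to compound 2 (0.42 log units; beyond the scatter), put 4-fluorophenyl in place of 2-methylprop-1-en-1-yl. It does not test a change on that aromatic ring, so it bears on this change only indirectly. No sizeable move in this assay is therefore expected in either direction, and a further limit reading is likely. The expected step is a number no higher from compound 2 to compound 3 (the limit leaves the size open). For compound 3 the estimated value is 10000 nM, with an expected range from 3500 nM to 30000 nM.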

Compound 3, half-maximal inhibitory concentration: > 10000 nM
Compound 3 was reported as a limit; the forecaster's own chance of this, stated with the estimate: 60%; the middle value lies on the limit itself.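

In this assay compound 3 gives > 10000 nM, a limit and not a number. Compound 2 and compound 3 are both limits, and the step between them cannot be read. Putting 4-cyanophenyl in place of 2-methylprop-1-en-1-yl gives an at least 2.6-fold higher number from compound 1 to compound 3 (0.42 log units; beyond the scatter), so the rise seen with 4-fluorophenyl is not confined to the fluoro compound, and the two benzyl ethers now share the same reading: the limit of > 10000 nM in this assay, at which 2 of the 3 values shown sit.

Any difference between fluoro and cyano on that aromatic carbon stays open, with no number for either compound. Also open, on these data alone, is whether an amine or a carboxylic acid in that place, or a longer chain in place of the 2-methylprop-1-en-1-yl, would give a reading that is a number rather than a limit.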